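Trimethoxyphenyl pyrazole chalcones: dimethoxyphenyl for dichlorophenyl

This account rests on a few compounds, and the source may have more. Where it says the series, first, only, none or still open, it means among the compounds named here.

Compound 1 `COc1cc(-c2cc(/C=C/C(=O)c3ccc(Cl)c(Cl)c3)[nH]n2)cc(OC)c1OC` is examined in a functional assay on CAKI-1 cells (Homo sapiens) for inhibition, read by sulforhodamine B assay, with a stated time of 48 h (on this read-out higher numbers stand for weaker inhibition of growth and lower numbers for stronger inhibition of growth), where compound 1 gives 16900 nM. Two further members of the series are shown. Compound 2 `COc1ccc(-c2cc(/C=C/C(=O)c3ccc(N)cc3)[nH]n2)cc1OC` carries no result in this assay, the entry reading "not determined" (no result reported). Compound 3 `COc1ccc(-c2cc(/C=C/C(=O)c3ccc(N)cc3)[nH]n2)cc1` differs from compound 1 at several places. In this assay compound 3 gives 1320 nM. Among the numbers shown, compound 1 stands at the higher of the two, with compound 3 at a lower number by a gap beyond the scatter, so compound 1 is the weaker inhibitor of growth of the pair.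

Compound 4 `COc1ccc(C(=O)/C=C/c2cc(-c3cc(OC)c(OC)c(OC)c3)n[nH]2)cc1OC` has not yet been measured. Its difference from compound 1 is 3,4-dimethoxyphenyl in place of 3,4-dichlorophenyl on a carbonyl carbon. Within the data shown here, no single-place step between measured compounds is available to calibrate this change; compound 3 shows only that a lower number is reachable with other groups on the carbonyl carbon and on the core.

In this assay the step from compound 1 to compound 4 is expected to be modest and toward a lower number, near the edge of the scatter, a 2.1-fold lower number from compound 1 to compound 4 (0.32 log units; beyond the scatter). Compound 4 is thus estimated at 8000 nM, within a range of 2500 nM to 25000 nM.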

Compound 4, concentration for 50% growth inhibition: 2200 nM
Estimate against measurement, compound 4: 3.6-fold (0.56 log units) above; the whole stated range lies above it.
By their numbers in this assay, from the lowest: compounds 3 and 4 (each within the scatter of the next); then compound 1.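

On the carbonyl carbon of the shared core, 3,4-dimethoxyphenyl in place of 3,4-dichlorophenyl gives a 7.7-fold lower number from compound 1 to compound 4 (0.89 log units; beyond the scatter) in this assay. This is the only single-place step in the compounds shown, and it establishes that the group on this carbonyl carbon can shift the growth-inhibition number beyond the scatter while the rest of compound 1 stays unchanged. Nothing measured here accounts for the size or direction of this step.

Left open is how far the step depends on the methoxy groups themselves: 3,4-difluorophenyl, 3,4-dihydroxyphenyl or 4-methoxyphenyl on the same carbonyl carbon, each on the core of compound 1, would test that on a single core. Among these compounds, a single pair also cannot show whether the change would carry over to other cores, such as the one in compound 3, so the step is best read for now as a result on the core of compound 1 alone.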